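This account rests on a few compounds, and the source may have more. Where it says the series, first, only, none or still open, it means among the compounds named here.

Working notes on the series. Compound 1 `OC[C@H]1O[C@@H](n2cnc3c(NCc4ccc(Cl)cc4Cl)ncnc32)[C@H](O)[C@@H]1O` and compound 2 `OC[C@H]1O[C@@H](n2cnc3c(NCc4ccc(Cl)c(Cl)c4)ncnc32)[C@H](O)[C@@H]1O` share the core with compound 3 `COc1cc(CNc2ncnc3c2ncn3[C@@H]2O[C@H](CO)[C@@H](O)[C@H]2O)cc(OC)c1` and differ only on the saturated chain carbon bound to a nitrogen on an aromatic ring. In a functional assay on B16 cells (Mus musculus) for antiproliferative activity, with a stated time of 72 h (on this read-out lower numbers stand for stronger inhibition and higher numbers for weaker inhibition), compound 1 reaches only the limit > 166000 nM. In this assay compound 2 likewise reaches only the limit > 166000 nM. The step that the two limits leave unreadable from compound 1 to compound 2 therefore cannot be sized. Going by the values given here, for compound 3 this assay reports "not determined" (no result reported), so it has no number of its own; the only evidence is the limit of > 166000 nM in this assay, at which 2 of the 3 values shown sit. Compound 4 `COc1cccc(CNc2ncnc3c2ncn3[C@@H]2O[C@H](CO)[C@@H](O)[C@H]2O)c1O` differs from compound 3 by 2-hydroxy-3-methoxyphenyl in place of 3,5-dimethoxyphenyl on a saturated chain carbon bound to a nitrogen on an aromatic ring. Among the compounds with values here, no measured step bears on this change, and the direction is not readable; no shift beyond the scatter can be claimed. Compound 4 is expected to give about 150000 nM in this assay, most likely again only a limit, within 30000 nM to 500000 nM.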

Compound 4, half-maximal inhibitory concentration: > 166000 nM
Compound 4: no number, only a limit (the forecaster's own chance of this, stated with the estimate: 70%); middle value at least 1.1-fold (0.04 log units) from the limit.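

In this assay compound 4 gives only a limit, > 166000 nM. Its steps from compound 1 and compound 2 cannot be read. Whether any of these groups changes the read-out stays open, with one thing to go on: the limit of > 166000 nM in this assay, at which 3 of the 4 values shown sit.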